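Notes on the aryl amide series, compound 4 ahead

The source may report more compounds than this note shows. Statements on the series, on what has been measured and on what is new or still open speak of the compounds shown alone.

Measured so far:
- compound 1 `O=C(CN1CCN(c2nnc(Cc3ccncc3)c3ccccc23)CC1)Nc1ccc(F)c(F)c1`: 0.84 nM
- compound 2 `O=C(CN1CCN(c2nnc(Cc3ccccc3)c3ccccc23)CC1)Nc1ccc(F)c(F)c1`: 2750 nM
- compound 3 `O=C(CN1CCN(c2nnc(Cc3ccccc3)c3ccccc23)CC1)Nc1ccc(F)c(C(F)(F)F)c1`: 760 nM

All three were tested in a functional assay on MDA-MB-231 cells (Homo sapiens) for cytotoxicity, read by MTT assay, with a stated time of 72 h; a lower number here means a stronger inhibitor, a higher number a weaker inhibitor. Compound 1 stands lowest of the three numbers; the nearest is compound 3, the furthest compound 2. The gap is set mainly by a 3300-fold higher number from compound 1 to compound 2 (3.52 log units; beyond the scatter), which is the large step in this set. The aryl amide end has been varied once, in a 3.6-fold lower number from compound 2 to compound 3 (0.56 log units; beyond the scatter), a modest step and the only one that touches the part changed here.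

Compound 4 `O=C(CN1CCN(c2nnc(Cc3ccncc3)c3ccccc23)CC1)Nc1cc(C(F)(F)F)ccc1Cl` keeps the core of compound 1 and changes the aryl amide end: 2-chloro-5-(trifluoromethyl)phenyl in place of 3,4-difluorophenyl on an amide-type nitrogen. For the measured compounds named here, no measured step covers this exact exchange; the single step on the aryl amide end is the one from compound 2 to compound 3, which was modest and in the lower direction, while the change here carries both a trifluoromethyl and a chlorine in new places. Compound 1 sits so low that a step in either direction is plausible, and the expected size, based on the step from compound 2 to compound 3, is a 2.4-fold higher number from compound 1 to compound 4 (0.38 log units; beyond the scatter), a modest shift with wide uncertainty. The expected value for compound 4 is therefore 2 nM, with a range of 0.3 nM to 15 nM.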

Compound 4, half-maximal inhibitory concentration: 3.7 nM
The estimate for compound 4 lay 1.9-fold (0.27 log units) below the measured number, within the range that was stated.
By their numbers in this assay, from the lowest: compound 1; then compound 4; then compound 3; then compound 2.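

Compound 4 shows that the aryl amide end accepts 2-chloro-5-(trifluoromethyl)phenyl, with 11 heavy atoms against 8 in 3,4-difluorophenyl, while the number in this assay stays low: the exchange gives a 4.4-fold higher number from compound 1 to compound 4 (0.64 log units; beyond the scatter). That modest step is much smaller than a 3300-fold higher number from compound 1 to compound 2 (3.52 log units; beyond the scatter), so among the changes read from compound 1, the loss of pyridin-4-yl remains the dominant one, and the aryl amide end has now been varied with the pyridin-4-yl group in place as well as with phenyl. No measured evidence bears on why this exchange raises the number or on why the size of the step is so limited.

The chlorine and the trifluoromethyl enter together, so their separate shares of the step cannot be read from these compounds, and the exchange on the pyridin-4-yl compounds cannot be set directly against a 3.6-fold lower number from compound 2 to compound 3 (0.56 log units; beyond the scatter), which is a different exchange on the phenyl compounds. Also open, as far as these compounds go, is whether an amine or a carboxylic acid on the aryl ring of the amide would keep the number near that of compound 4, at 3.7 nM.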